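A few compounds are considered here, and "the series" means these few. Any claim that something is new, unique, unknown or untested is made for them only; others in the source may bear on it.

The measured compounds are:
Compound 1, `COc1ccc(/C=C/C(=O)Nc2cc(C(=O)c3cc(OC)c(OC)c(OC)c3)ccc2OC)cc1` — in a functional assay on HT-29 cells (Homo sapiens) for cytotoxicity, read by MTT assay, with a stated time of 72 h (a lower number here means a stronger inhibitor, a higher number a weaker inhibitor), compound 1 gives 5010 nM.
Compound 2, `C#CCOc1cccc(/C=C/C(=O)Nc2cc(C(=O)c3cc(OC)c(OC)c(OC)c3)ccc2OC)c1` — in this assay compound 2 gives 7400 nM.
Compound 3, `COc1ccc(/C=C/C(=O)Nc2cc(C(=O)c3cc(OC)c(OC)c(OC)c3)cc(OC)c2OC)cc1` — in this assay compound 3 gives 3800 nM.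

Compound 3 has the lowest number of the three, but its gaps to compound 1 and to compound 2 both lie within the scatter, so no order among them can be claimed. Compound 4, `C#CCOc1cccc(/C=C/C(=O)Nc2cc(C(=O)c3cc(OC)c(OC)c(OC)c3)cc(OC)c2OC)c1`, differs from compound 3 by 3-(propargyloxy)phenyl in place of 4-methoxyphenyl on a double-bonded chain carbon bound to a double-bonded chain carbon. The same change has been measured once already, on the core without the added methoxy: a 1.5-fold higher number from compound 1 to compound 2 (0.17 log units; within the scatter). The other measured step, a 1.3-fold lower number from compound 1 to compound 3 (0.12 log units; within the scatter), shows that the methoxy carried by compound 3 and compound 4 made little difference on its own. Taken together, these two steps lead to the expectation that compound 4 will show a step of about the same size as the earlier one, a 1.5-fold higher number from compound 3 to compound 4 (0.17 log units; within the scatter), that is a somewhat higher number, not clearly beyond the scatter. Compound 4 is therefore estimated at 5600 nM, with a range of 2500 nM to 12500 nM.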

Compound 4, half-maximal inhibitory concentration: 8100 nM
Beside the measured number, compound 4's estimate is 1.4-fold (0.16 log units) below it; the range from low to high includes it.
By their numbers in this assay, from the lowest: compounds 3, 1, 2 and 4 (each within the scatter of the next, the first and the last beyond it).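

In this assay, 3-(propargyloxy)phenyl in place of 4-methoxyphenyl on a double-bonded chain carbon bound to a double-bonded chain carbon now gives a step beyond the scatter, a 2.1-fold higher number from compound 3 to compound 4 (0.33 log units; beyond the scatter), whereas the step on the core without the added methoxy stayed within it. The two steps still agree, so the change points the same way on both cores and the added methoxy does not alter its effect measurably: the same change on two cores in this assay, a 1.5-fold higher number (0.17 log units; within the scatter) from compound 1 to compound 2 and a 2.1-fold higher number (0.33 log units; beyond the scatter) from compound 3 to compound 4, 1.4-fold (0.16 log units) apart, within the scatter of two such steps. The added methoxy itself again makes no readable difference, a 1.1-fold higher number from compound 2 to compound 4 (0.04 log units; within the scatter), matching its earlier step: the same change on two cores in this assay, a 1.3-fold lower number (0.12 log units; within the scatter) from compound 1 to compound 3 and a 1.1-fold higher number (0.04 log units; within the scatter) from compound 2 to compound 4, 1.4-fold (0.16 log units) apart, within the scatter of two such steps.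

The compounds shown leave open whether the triple bond of 3-(propargyloxy)phenyl matters or whether any ether on this ring would serve as well. A phenyl ring carrying an amine or a carboxylic acid, or a longer chain ending in a triple bond, would address this.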